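Swapping the aryl substituent from nitro to cyclopropyl

A few compounds are considered here, and "the series" means these few. Any claim that something is new, unique, unknown or untested is made for them only; others in the source may bear on it.

Of the compounds shown here, two with a shared core have been measured so far. Compound 1 `CC1CC/C(=N\Nc2ccc(Br)cc2)c2ncc(C(=O)O)c(=O)n21` carries a bromo group on its aromatic ring, and in a functional assay on the whole organism for inhibition, with Rattus norvegicus as the target (on this read-out higher numbers stand for an effect only at larger amounts of compound and lower numbers for an effect already at smaller amounts), compound 1 gives 0.8 umol/kg. Compound 2 `CC1CC/C(=N\Nc2ccc([N+](=O)[O-])cc2)c2ncc(C(=O)O)c(=O)n21` carries a nitro group in the same place, and in this assay compound 2 gives 0.8 umol/kg. The step of no change at the digits printed from compound 1 to compound 2 (within the scatter) shows that exchanging bromo for nitro made no difference beyond the scatter, so compound 2 stands level with compound 1.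

Compound 3 `CC1CC/C(=N\Nc2ccc(C3CC3)cc2)c2ncc(C(=O)O)c(=O)n21` differs from compound 2 by cyclopropyl in place of nitro on an aromatic carbon. Among the compounds with values here, no measured step involves a cyclopropyl group, so the only guidance is the step from compound 1 to compound 2, in which one small group replaced another on the same aromatic carbon without any shift in this assay. On that basis the change to cyclopropyl is expected to leave the read-out essentially where it is, with no step beyond the scatter in either direction, expressed as no change at the digits printed from compound 2 to compound 3 (within the scatter). Compound 3 is therefore estimated to give 0.8 umol/kg in this assay, within a range from 0.3 umol/kg to 2.5 umol/kg.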

Compound 3, dose for 50% inhibition: 41.1 umol/kg
Estimate against measurement, compound 3: 51-fold (1.71 log units) below; measured number outside the range, above it.
By their numbers in this assay, from the lowest: compounds 1 and 2 (each within the scatter of the next); then compound 3.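

The aromatic carbon that carried bromo and nitro is not indifferent to what sits on it, even though those two groups left compound 1 and compound 2 level. In this assay cyclopropyl brings a large loss, seen both against nitro, as a 51-fold higher number from compound 2 to compound 3 (1.71 log units; beyond the scatter), and against bromo, as a 51-fold higher number from compound 1 to compound 3 (1.71 log units; beyond the scatter), so far more compound is needed for the same effect. Nitro and cyclopropyl have the same count of heavy atoms, so that count alone does not separate them, but nitro has nitrogen, oxygen and hydrogen-bond acceptors where cyclopropyl has only carbon, and no measurement shown here explains the jump.

Within the data shown here, with only three groups at this place, it remains open whether the loss belongs to cyclopropyl itself or extends to other all-carbon groups such as methyl, isopropyl or a longer chain like butyl. An amine, a methoxy group or a nitrile on the same carbon would help show whether groups holding nitrogen or oxygen stay level with compound 2 or fall away towards compound 3.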